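Acrylamide Series: Changing the Aryl Group on the Amine Nitrogen

A few compounds are considered here, and "the series" means these few. Any claim that something is new, unique, unknown or untested is made for them only; others in the source may bear on it.

Of the compounds shown here, three sharing one core have been measured in a functional assay on PC-3 cells (Homo sapiens) for inhibition, read by MTT assay, with a stated time of 72 h; on this read-out lower numbers stand for stronger inhibition and higher numbers for weaker inhibition. Going by the values given here, compound 1 `O=C(CSc1nc(Nc2ccccc2)c2ccccc2n1)Nc1ccccc1Br` gives 19800 nM, and compound 2 `O=C(CSc1nc(Nc2ccccc2)c2ccccc2n1)Nc1ccc(Cl)cc1` gives 12900 nM; the single step between them, a 1.5-fold lower number from compound 1 to compound 2 (0.19 log units; within the scatter), stays within the scatter. Compound 3 `C=CC(=O)Nc1cccc(NC(=O)CSc2nc(Nc3cccc(F)c3)c3ccccc3n2)c1` gives 5370 nM, the lowest of the three numbers, beyond the scatter from both compound 1 and compound 2. Compound 4 `C=CC(=O)Nc1cccc(NC(=O)CSc2nc(Nc3ccc(Cl)cc3Cl)c3ccccc3n2)c1` differs from compound 3 in one place: 2,4-dichlorophenyl in place of 3-fluorophenyl on a nitrogen on an aromatic ring. Among the compounds with values here, no measured step alters the group on this nitrogen; the only measured step concerns the amide-type nitrogen and was within the scatter. Compound 4 is therefore expected to move by only a 1.2-fold lower number from compound 3 to compound 4 (0.08 log units; within the scatter), nothing beyond the scatter. The estimate for compound 4 in this assay is 4500 nM, ranging from 1500 nM to 13000 nM.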

Compound 4, half-maximal inhibitory concentration: 25700 nM
Beside the measured number, compound 4's estimate is 5.7-fold (0.76 log units) below it, and the stated range ends below it.
By their numbers in this assay, from the lowest: compound 3; then compounds 2, 1 and 4 (each within the scatter of the next).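

In this assay the group on a nitrogen on an aromatic ring turns out to matter: a 4.8-fold higher number from compound 3 to compound 4 (0.68 log units; beyond the scatter) is a step beyond the scatter when 2,4-dichlorophenyl replaces 3-fluorophenyl. Going by these compounds alone, the only earlier step, a 1.5-fold lower number from compound 1 to compound 2 (0.19 log units; within the scatter), concerned the amide-type nitrogen and stayed within the scatter. No evidence at hand accounts for this step.

The compounds shown leave open whether a methoxy group or an amine on this aryl ring would keep the number near that of compound 3. They also leave open whether the same exchange would act alike on the compounds lacking the acrylamide.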